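Chlorophenyl in place of difluorophenyl on the ring nitrogen

The source may hold more compounds than are shown below. What is called first, only, known or untested is meant among the compounds shown, and "the series" means these compounds.

Three compounds share one core and differ only in the aromatic group on an amine nitrogen in a ring. In a functional assay on CHO cells with adenosine receptor A1 (Homo sapiens) as the target, read by cAMP accumulation and immunoassay, with a stated time of 6 min, tested at 10 uM (on this read-out higher numbers stand for a weaker effect at the one concentration tested and lower numbers for a stronger effect), compound 1 `Nc1scc(CN2CCN(c3cccc(C(F)(F)F)c3)CC2)c1C(=O)c1ccc(Cl)cc1` gives -80%, compound 2 `Nc1scc(CN2CCN(c3ccc(Cl)c(C(F)(F)F)c3)CC2)c1C(=O)c1ccc(Cl)cc1` gives -60%, and compound 3 `Nc1scc(CN2CCN(c3cc(F)cc(F)c3)CC2)c1C(=O)c1ccc(Cl)cc1` gives -79%. Compound 3 therefore stands second highest of the three numbers, close to compound 1 and apart from compound 2. Adding chloro in place of hydrogen on an aromatic carbon gave a number 20 percentage points higher from compound 1 to compound 2 (beyond the scatter). Compound 4 `Nc1scc(CN2CCN(c3cccc(Cl)c3)CC2)c1C(=O)c1ccc(Cl)cc1` carries 3-chlorophenyl in place of 3,5-difluorophenyl on an amine nitrogen in a ring. Because earlier swaps of this aryl group gave only a number 1 percentage points higher from compound 1 to compound 3 (within the scatter) and a number 19 percentage points lower from compound 2 to compound 3 (beyond the scatter), little shift is expected here, and the expected step is a number 3 percentage points higher from compound 3 to compound 4 (within the scatter), within the scatter. Compound 4 is thus estimated at -76%, ranging from -92% to -58%.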

Compound 4, a percentage reported as activity, at one concentration (the size of the read-out at that concentration, not a potency): -77%
For compound 4 the middle estimate is 1 percentage points above the measured one, within the range that was stated.
By their numbers in this assay, from the lowest: compounds 1, 3 and 4 (each within the scatter of the next); then compound 2.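

In this assay the 3-chlorophenyl group on the amine nitrogen matches the 3,5-difluorophenyl group, giving a number 2 percentage points higher from compound 3 to compound 4 (within the scatter). Chloro in place of trifluoromethyl on an aromatic carbon likewise gives a number 3 percentage points higher from compound 1 to compound 4 (within the scatter), so the ring tolerates these different single changes, while 3-chlorophenyl in place of 4-chloro-3-(trifluoromethyl)phenyl gives a number 17 percentage points lower from compound 2 to compound 4 (beyond the scatter), leaving compound 2 as the one that stands apart. Nothing measured here gives a reason for this. Still open, on these data alone, is whether a methoxy group or an amine on this phenyl ring, or a pyridine ring in its place, would fit the same picture.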